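The compounds below may be only part of what the source reports. "The series", "measured", "known", "first", "only" and "open" are said of these compounds alone.

Measured so far in a functional assay on CHO cells for antagonist activity at prostaglandin E2 receptor EP1 subtype (Homo sapiens), read by FLIPR and calcium flux; on this read-out lower numbers stand for stronger inhibition and higher numbers for weaker inhibition:
compound 1 `COc1ccc(Cc2nnc(CN(c3cccc(Cl)c3C)S(=O)(=O)c3ccc(C)cc3)o2)cc1` gives 39.8 nM;
compound 2 `Cc1ccc(S(=O)(=O)N(Cc2nnc(Cc3ccc(Cl)cc3Cl)o2)c2cccc(Cl)c2C)cc1` gives 1000 nM.

Compound 2 stands as the highest of the two numbers; its nearest neighbour is compound 1, reached by the step of a 25-fold higher number from compound 1 to compound 2 (1.40 log units; beyond the scatter).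

Compound 3 `COc1ccc(Nc2nnc(CN(c3cccc(Cl)c3C)S(=O)(=O)c3ccc(C)cc3)o2)cc1` is the next compound to be measured. It differs from compound 2 by (4-methoxyphenyl)amino in place of 2,4-dichlorobenzyl on an aromatic carbon.

For the measured compounds named here, only one measured step bears on this change: a 25-fold higher number from compound 1 to compound 2 (1.40 log units; beyond the scatter). That step exchanged the 4-methoxyphenyl ring for the 2,4-dichlorophenyl ring on the saturated chain carbon and was large. Going by the values given here, the step from compound 2 to compound 3 brings the 4-methoxyphenyl ring back, but attached through an amino nitrogen rather than through the chain carbon; no measured pair covers this attachment. The expected step is therefore a large fall in the number, a 17-fold lower number from compound 2 to compound 3 (1.22 log units; beyond the scatter), with wide uncertainty. Compound 3 is expected near 60 nM, between 15 nM and 400 nM.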

Compound 3, inhibition constant: 79.4 nM
Estimate against measurement, compound 3: 1.3-fold (0.12 log units) below; measured number inside the range.
By their numbers in this assay, from the lowest: compounds 1 and 3 (each within the scatter of the next); then compound 2.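

In this assay, the place on the aromatic carbon of the five-membered ring, next to the ring nitrogen and the ring oxygen, again gives a large step when 2,4-dichlorobenzyl leaves, here for (4-methoxyphenyl)amino (a 13-fold lower number from compound 2 to compound 3 (1.10 log units; beyond the scatter)). With the 4-methoxyphenyl ring kept, the exchange of 4-methoxybenzyl for (4-methoxyphenyl)amino stays within the scatter (a 2.0-fold higher number from compound 1 to compound 3 (0.30 log units; within the scatter)), so these compounds do not separate a chain carbon from an amino nitrogen as the link to that ring. Nothing at hand gives a cause for either step.

Ring and link change together between compound 2 and compound 3, so it remains open how a 2,4-dichlorophenyl ring would read on an amino nitrogen. From the compounds shown here alone, how an ether oxygen, a methylated amine or a longer chain would compare as the link also remains open.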